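This account rests on a few compounds, and the source may have more. Where it says the series, first, only, none or still open, it means among the compounds named here.

Among the compounds with values here, compound 2, `COc1ccc(-c2cc3ccccc3nc2/C=C/C(=O)c2cccs2)cc1`, gives 920 nM in a functional assay on A549 cells (Homo sapiens) for antiproliferative activity, read by XTT assay, with a stated time of 72 h (on this read-out higher numbers stand for weaker inhibition and lower numbers for stronger inhibition), the lower of the two numbers known so far. Compound 1, `COc1ccc(-c2cc3ccccc3nc2/C=C/C(=O)c2ccc(N)cc2)cc1`, gives 7530 nM, and an 8.2-fold lower number from compound 1 to compound 2 (0.91 log units; beyond the scatter). Compound 3, `COc1ccc(-c2cc3ccccc3nc2/C=C/C(=O)c2ccsc2)cc1`, differs from compound 2 by thiophen-3-yl in place of thiophen-2-yl on a carbonyl carbon. Within the data shown here, no measured step exchanges one thiophenyl for another: the single known step replaced a quite different group on the same carbonyl carbon, so it does not show what this rearrangement does. The step expected is a 1.2-fold higher number from compound 2 to compound 3 (0.08 log units; within the scatter), nothing beyond the scatter. Compound 3 is estimated at 1100 nM, within a range of 450 nM to 2800 nM.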

Compound 3, half-maximal inhibitory concentration: 8210 nM
The estimate for compound 3 lay 7.5-fold (0.87 log units) below the measured number, and the stated range ends below it.
By their numbers in this assay, from the lowest: compound 2; then compounds 1 and 3 (each within the scatter of the next).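

In this assay, the point at which the thiophene ring is joined to the carbonyl carbon matters, since thiophen-3-yl in place of thiophen-2-yl gives an 8.9-fold higher number from compound 2 to compound 3 (0.95 log units; beyond the scatter) although both groups have the same atoms. The benefit seen earlier therefore belongs to thiophen-2-yl, not to thiophene as such, and the other step (a 1.1-fold higher number from compound 1 to compound 3 (0.04 log units; within the scatter)) shows thiophen-3-yl no better than 4-aminophenyl. No measurement here explains this gap. Still open, on these data alone, is whether another ring on this carbonyl carbon, such as furan-2-yl or pyridin-2-yl, behaves like thiophen-2-yl or like thiophen-3-yl.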